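Swapping an aryl ring for a hydroxypropyl pyrazole

A few compounds are considered here, and "the series" means these few. Any claim that something is new, unique, unknown or untested is made for them only; others in the source may bear on it.

Compound 3 `COc1ncc(-c2ccc3ncnc(Nc4ccc(OCCO)c(Cl)c4)c3c2)cc1NS(=O)(=O)c1ccc(F)cc1F` was tested in a functional assay on HCT-116 cells (Homo sapiens) for antiproliferative activity, read by sulforhodamine B assay, with a stated time of 72 h (on this read-out lower numbers stand for stronger inhibition and higher numbers for weaker inhibition), where it gives 7320 nM. Among the three measured compounds this is the second highest number: compound 1 `COc1ncc(-c2ccc3ncnc(Nc4ccc(OCCO)c(F)c4)c3c2)cc1NS(=O)(=O)c1ccc(F)cc1F` gives 9160 nM, a gap to compound 3 that stays within the scatter, while compound 2 `COc1ncc(-c2ccc3ncnc(Nc4cnn(CC(=O)O)c4)c3c2)cc1NS(=O)(=O)c1ccc(F)cc1F` gives 1540 nM, and the step from compound 2 to compound 3 is a 4.8-fold higher number from compound 2 to compound 3 (0.68 log units; beyond the scatter).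

Compound 4 `COc1ncc(-c2ccc3ncnc(Nc4cnn(CCCO)c4)c3c2)cc1NS(=O)(=O)c1ccc(F)cc1F` differs from compound 3 in one place: 1-(3-hydroxypropyl)-1H-pyrazol-4-yl in place of 3-chloro-4-(2-hydroxyethoxy)phenyl on a nitrogen on an aromatic ring. Of the measured steps, the one that bears on this change is a 4.8-fold higher number from compound 2 to compound 3 (0.68 log units; beyond the scatter), since compound 2 already carries a pyrazole at the same nitrogen, although with a carboxymethyl group instead of a 3-hydroxypropyl group. The step from compound 1 to compound 3, a 1.3-fold lower number from compound 1 to compound 3 (0.10 log units; within the scatter), shows that chloro against fluoro on the departing ring makes little difference. Because the step from compound 2 to compound 3 was a 4.8-fold higher number from compound 2 to compound 3 (0.68 log units; beyond the scatter), a lower number is expected for compound 4 in this assay, of modest size, with the unknown effect of the altered pyrazole substituent widening the range. The expected value for compound 4 is 2200 nM, between 600 nM and 8000 nM, which is an expected step of a 3.3-fold lower number from compound 3 to compound 4 (0.52 log units; beyond the scatter).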

Compound 4, half-maximal inhibitory concentration: 480 nM
For compound 4 the middle estimate is 4.6-fold (0.66 log units) above the measured one, and the stated range ends above it.
By their numbers in this assay, from the lowest: compound 4; then compound 2; then compounds 3 and 1 (each within the scatter of the next).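

In this assay the pyrazole on this nitrogen now beats the chloro aryl ring by a wide margin (a 15-fold lower number from compound 3 to compound 4 (1.18 log units; beyond the scatter)) and the fluoro aryl ring by a similar one (a 19-fold lower number from compound 1 to compound 4 (1.28 log units; beyond the scatter)), so a large gain is possible from this ring exchange alone. The earlier compounds shown here also could not show that the chain on the pyrazole matters, yet with the pyrazole kept, the 2-hydroxyethyl in place of carboxy on the chain carbon bound to the aromatic nitrogen gives a further clear shift (a 3.2-fold lower number from compound 2 to compound 4 (0.51 log units; beyond the scatter)), which leaves compound 4 with the lowest number of the four. Nothing shown here gives a measured reason for either shift.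

Only two pyrazole chains appear, the carboxymethyl and the 3-hydroxypropyl, and they differ in both their end group and their make-up, so the role of the hydroxyl itself stays unsettled. As far as these compounds go, whether a shorter 2-hydroxyethyl chain, a longer 4-hydroxybutyl chain or an amine at the chain end would lower the number further remains open, as does whether the pyrazole without any chain, carrying only a methyl group, would keep the gain.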